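Phenylethynyl in Place of Benzodioxinyl at the Same Carbon

The source may hold more compounds than are shown below. What is called first, only, known or untested is meant among the compounds shown, and "the series" means these compounds.

For the measured compounds named here, compound 2 `CC(C(=O)NCc1ccc(C(F)(F)F)nc1-c1ccc2c(c1)OCCO2)c1ccc(NS(C)(=O)=O)c(F)c1` gives 5 nM in an assay on CHO cells for antagonist activity at transient receptor potential cation channel subfamily V member 1 (Homo sapiens), read by FLIPR (on this read-out lower numbers stand for stronger inhibition and higher numbers for weaker inhibition), the highest of the two numbers so far. Going by the values given here, its nearest neighbour, compound 1 `CC(C(=O)NCc1ccc(C(F)(F)F)nc1-c1cccc(Cl)c1)c1ccc(NS(C)(=O)=O)c(F)c1`, gives 0.5 nM in this assay, and the only step between them, a 10-fold higher number from compound 1 to compound 2 (1.00 log units; beyond the scatter), shows that exchanging the group on this aromatic carbon next to the ring nitrogen moves the read-out by a modest but real amount.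

Among the compounds with values here, compound 3 `CC(C(=O)NCc1ccc(C(F)(F)F)nc1C#Cc1ccccc1)c1ccc(NS(C)(=O)=O)c(F)c1` has not yet been measured. 2-phenylethynyl in place of 2,3-dihydro-1,4-benzodioxin-6-yl on an aromatic carbon The one measured step that bears on this change is a 10-fold higher number from compound 1 to compound 2 (1.00 log units; beyond the scatter); it tells how much this position can shift the number, but no measured pair shows which way a 2-phenylethynyl group would take it. The author therefore expects a modest step at most, a 2.0-fold higher number from compound 2 to compound 3 (0.30 log units; within the scatter), with weakening slightly more likely than strengthening. Compound 3 is estimated at 10 nM, within 1.5 nM to 60 nM.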

Compound 3, inhibition constant: 0.8 nM
Estimate against measurement, compound 3: 13-fold (1.10 log units) above; the whole stated range lies above it.
By their numbers in this assay, from the lowest: compounds 1 and 3 (each within the scatter of the next); then compound 2.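

Replacing 2,3-dihydro-1,4-benzodioxin-6-yl with 2-phenylethynyl gives a 6.3-fold lower number from compound 2 to compound 3 (0.80 log units; beyond the scatter) in this assay, so a change at this carbon next to the ring nitrogen can lower the number as well as raise it, and a substituent with a triple bond outside the aromatic rings is accepted here. Set against the 3-chlorophenyl group, the same 2-phenylethynyl group gives a 1.6-fold higher number from compound 1 to compound 3 (0.20 log units; within the scatter), so this assay does not separate these two groups, and of the three compounds only compound 2 stands apart. Nothing shown accounts for the difference between these groups.

The compounds shown leave open how an unsubstituted phenyl, a 2-phenylethyl chain or an amine such as morpholine would read at this carbon. They also leave open whether a chlorine on the ring of the 2-phenylethynyl group would move the number.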